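The source may hold more compounds than are shown below. What is called first, only, known or untested is meant among the compounds shown, and "the series" means these compounds.

Measured so far:
compound 1, `CC(Sc1nnc(-c2ccncc2)s1)C(=O)Nc1ccc(Cl)cc1Cl` — > 50000 nM
compound 2, `CC(Sc1nnc(-c2ccncc2)s1)C(=O)Nc1ccc(Cl)cc1` — > 50000 nM
compound 3, `O=C(CSc1nnc(-c2ccncc2)s1)Nc1c(Cl)cccc1Cl` — "not determined" (no result reported)

In an ADME assay on BHK-21 cells (Mesocricetus auratus) for cytotoxicity, with a stated time of 3 days (a higher number here means that more compound is tolerated, a lower number that less compound is tolerated), compound 1 gives > 50000 nM, which is a limit of the assay rather than a number. Compound 2 gives > 50000 nM in this assay, again a limit. The step that the two limits leave unreadable from compound 1 to compound 2 is therefore unreadable; the change is hydrogen in place of chloro on an aromatic carbon. For compound 3 this assay reports "not determined" (no result reported); how its core differs from that of compound 1 is not broken down here.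

Compound 4, `O=C(CSc1nnc(-c2ccncc2)s1)Nc1ccccc1Cl`, is not yet measured. It differs from compound 3 by hydrogen in place of chloro on an aromatic carbon, the same change as that from compound 1 to compound 2. Since two of the three values sit at the limit of > 50000 nM in this assay, at which 2 of the 3 values shown sit, compound 4 is expected to sit at the limit as well, with an estimated value of 60000 nM (between 30000 nM and 200000 nM).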

Compound 4, half-maximal cytotoxic concentration: > 50000 nM
Compound 4 ended at the assay's limit (the forecaster's own chance of this, stated with the estimate: 80%); the middle value is on the limit's open side.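

Going by these compounds alone, no step from compound 3 to compound 4 can be read in this assay; compound 4 gives > 50000 nM, a limit and not a number. The compounds shown leave open whether removing a chloro group changes tolerance at all.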